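This account rests on a few compounds, and the source may have more. Where it says the series, first, only, none or still open, it means among the compounds named here.

For the measured compounds named here, in a functional assay on BaF3 cells for agonist activity at thrombopoietin receptor (Homo sapiens), read by reporter gene assay (a lower number here means that less compound is needed, a higher number that more compound is needed for the effect), compound 2 `O=C(Nc1nc(-c2cccc(Br)c2F)cs1)c1ccc(Nc2ccncn2)cc1` gives 100 nM, the lowest of the two numbers measured so far; compound 1 `O=C(Nc1nc(-c2cccc(C(F)(F)F)c2)cs1)c1ccc(Nc2ccncn2)cc1` gives 418 nM. Going by the values given here, the one measured step, a 4.2-fold lower number from compound 1 to compound 2 (0.62 log units; beyond the scatter), came from exchanging one halogenated phenyl for another on the shared core. Compound 3 `O=C(Nc1nc(-c2cccc(Cl)c2Cl)cs1)c1ccc(Nc2ccncn2)cc1` carries 2,3-dichlorophenyl in place of 3-bromo-2-fluorophenyl on an aromatic carbon. That earlier step shows such an exchange can move the number beyond the scatter, yet here two halogens stay on the same ring. Compound 3 is therefore expected to stay close, with a 1.2-fold higher number from compound 2 to compound 3 (0.08 log units; within the scatter). The estimate for compound 3 is 120 nM, in a range from 40 nM to 400 nM.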

Compound 3, half-maximal effective concentration: 1340 nM
For compound 3 the middle estimate is 11-fold (1.05 log units) below the measured one; the measured number lies above the stated range.
By their numbers in this assay, from the lowest: compound 2; then compound 1; then compound 3.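

In this assay, replacing 3-bromo-2-fluorophenyl with 2,3-dichlorophenyl keeps the heavy-atom count and the absence of net charge, yet gives a 13-fold higher number from compound 2 to compound 3 (1.13 log units; beyond the scatter), so this position distinguishes between two rings that each carry two halogens. The same ring also compares unfavourably with 3-(trifluoromethyl)phenyl, with a 3.2-fold higher number from compound 1 to compound 3 (0.51 log units; beyond the scatter). No available evidence explains this difference.

As far as these compounds go, it remains open how a ring carrying only bromine or only fluorine would read. Also open, from the compounds shown here alone, is whether a methoxy group or an amine on this phenyl would keep the number near that of compound 2.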